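The source may hold more compounds than are shown below. What is called first, only, known or untested is meant among the compounds shown, and "the series" means these compounds.

Series notes. Compound 1 `Cc1ccc(C(F)(F)F)cc1COc1cc(NC(=O)c2ccc(I)cc2)ccc1N(C)S(C)(=O)=O` and compound 2 `Cc1ccc(C(F)(F)F)cc1COc1cc(NC(=O)c2ccc3ccccc3c2)ccc1N(C)S(C)(=O)=O` share one core; compound 3 `COc1ccc(OC)c(COc2cc(NC(=O)c3ccc(I)cc3)ccc2N(C)S(=O)(=O)C(F)(F)F)c1` and compound 4 `COc1ccc(OC)c(COc2cc(NC(=O)c3ccc4ccccc4c3)ccc2N(C)S(=O)(=O)C(F)(F)F)c1` share another. The difference between the two cores is not broken down here.

In a functional assay on SK-BR-3 cells (Homo sapiens) for antiproliferative activity, read by MTT assay, with a stated time of 48 h (on this read-out higher numbers stand for weaker inhibition and lower numbers for stronger inhibition), compound 1 gives 3500 nM and compound 2 gives 18400 nM. The change between them, (naphthalen-2-yl in place of 4-iodophenyl on a carbonyl carbon), produced a step of a 5.3-fold higher number from compound 1 to compound 2 (0.72 log units; beyond the scatter).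

Going by the values given here, compound 3 gives 510 nM in this assay, the lowest of the three numbers measured so far, with compound 1 the nearest and compound 2 the furthest from it.

The change from compound 3 to compound 4 is naphthalen-2-yl in place of 4-iodophenyl on a carbonyl carbon, and its place line matches that of the earlier change word for word, so it is the same change made on the other core. Among the compounds with values here, with only one earlier example, the expectation rests on that single step: compound 4 is expected to show a step of about a 5.3-fold higher number from compound 3 to compound 4 (0.72 log units; beyond the scatter) in this assay, in line with the step from compound 1 to compound 2 of a 5.3-fold higher number from compound 1 to compound 2 (0.72 log units; beyond the scatter). Compound 4 is therefore estimated at 2700 nM, with a likely range from 1100 nM to 7500 nM.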

Compound 4, half-maximal inhibitory concentration: 200 nM
Compound 4: middle estimate off by 14-fold (1.13 log units), on the high side; measured number outside the range, below it.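

In this assay, naphthalen-2-yl in place of 4-iodophenyl on a carbonyl carbon gives a 2.6-fold lower number from compound 3 to compound 4 (0.41 log units; beyond the scatter), the opposite direction to the step on the core of compound 1. In this series, the change therefore does not carry from one core to the other in either size or direction: the same change on two cores in this assay, a 5.3-fold higher number (0.72 log units; beyond the scatter) from compound 1 to compound 2 and a 2.6-fold lower number (0.41 log units; beyond the scatter) from compound 3 to compound 4, 13-fold (1.13 log units) apart, beyond the scatter of two such steps This does not show which difference between the cores sets the outcome, and two pairs give no rule for predicting the step on a third core.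

Left open is which part of the core difference reverses the step: the methanesulfonyl against the trifluoromethanesulfonyl group, or the substituents on the benzyl ether. Also open, on these data alone, is how other groups on the carbonyl carbon would behave on either core, such as a phenyl ring carrying an amine or a carboxylic acid in place of the iodine.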